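The compounds below may be only part of what the source reports. "The series", "measured", "known", "first", "only" and "open" are said of these compounds alone.

Compound 1, `O=[N+]([O-])c1cc2c(OCCC3CCCCN3)c(-c3cccc(Cl)c3)c(O)nc2cc1Cl`: in a functional assay on cells (Pituitary gland cell) for antagonist activity at Gonadotropin-releasing hormone receptor (Rattus norvegicus) (a higher number here means a weaker inhibitor, a lower number a stronger inhibitor), compound 1 gives 40 nM.
Compound 2, `O=[N+]([O-])c1cc2c(OCCC3CCCCN3)c(-c3ccc4ccccc4c3)c(O)nc2cc1Cl`: in this assay compound 2 gives 53 nM.
Compound 3, `O=C(Nc1cc2c(OCCC3CCCCN3)c(-c3ccc4ccccc4c3)c(O)nc2cc1Cl)NC1CC1`: in this assay compound 3 gives 68 nM.

Compound 3 holds the highest of the three numbers, but its gap to compound 2 and its gap to compound 1 are both within the usual scatter, so the three compounds cannot be ranked against one another on these numbers. Compound 4, `O=C(Nc1cc2c(OCCC3CCCCN3)c(-c3cccc(Br)c3)c(O)nc2cc1Cl)NC1CC1`, differs from compound 3 in one place: 3-bromophenyl in place of naphthalen-2-yl on an aromatic carbon. Within the data shown here, one measured step bears directly on this change: a 1.3-fold higher number from compound 1 to compound 2 (0.12 log units; within the scatter), which put naphthalen-2-yl in place of 3-chlorophenyl and thus runs in the opposite direction, and it stayed within the scatter. The other step, a 1.3-fold higher number from compound 2 to compound 3 (0.11 log units; within the scatter), concerns a different position and was also within the scatter. Accordingly the expected step of a 1.2-fold lower number from compound 3 to compound 4 (0.09 log units; within the scatter) is small, with no direction that can be asserted beyond the scatter. Compound 4 is therefore estimated at 55 nM in this assay, with a range from 25 nM to 120 nM.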

Compound 4, half-maximal inhibitory concentration: 6 nM
For compound 4 the middle estimate is 9.2-fold (0.96 log units) above the measured one; measured number outside the range, below it.
By their numbers in this assay, from the lowest: compound 4; then compounds 1, 2 and 3 (each within the scatter of the next).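

Among these compounds, on the aromatic carbon ortho to the 2-(piperidin-2-yl)ethoxy group and to the hydroxy group, 3-bromophenyl in place of naphthalen-2-yl gives an 11-fold lower number from compound 3 to compound 4 (1.05 log units; beyond the scatter) in this assay, the first step here to lie beyond the scatter. The earlier change at this carbon, a 1.3-fold higher number from compound 1 to compound 2 (0.12 log units; within the scatter), stayed within the scatter, so this position is not indifferent to its aryl group once the (cyclopropylcarbamoyl)amino group is present. Nothing measured here explains the size of the step.

The compounds shown do not separate the part played by bromine from that of the single ring in place of two, nor say whether the same step would appear with nitro on the core. As far as these compounds go, whether 3-iodophenyl, 3-methylphenyl or an unsubstituted phenyl would behave like 3-bromophenyl also stays open.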